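Adding a Methoxy Group on a Second Core

The compounds below may be only part of what the source reports. "The series", "measured", "known", "first", "only" and "open" are said of these compounds alone.

Three compounds were tested in a functional assay on ileum for antagonist activity at histamine H1 receptor (Cavia porcellus), tested at 0.5 mg/mL; on this read-out lower numbers stand for an effect already at smaller amounts and higher numbers for an effect only at larger amounts of compound. Compound 1 `Cc1cc(=O)oc2ccc(OCC(O)CN3CCN(c4ccccc4)CC3)cc12` gives 0.0063 ug/mL. Compound 2 `COc1ccccc1N1CCN(CC(O)COc2ccc3oc(=O)cc(C)c3c2)CC1` gives 0.0062 ug/mL in this assay. Compound 2 differs from compound 1 only by methoxy in place of hydrogen on an aromatic carbon, and this change gave a 1.0-fold lower number from compound 1 to compound 2 (0.01 log units; within the scatter). Compound 3 `O=c1cc(-c2ccccc2)c2ccc(OCC(O)CN3CCN(c4ccccc4)CC3)cc2o1` is built on a different core; the difference between the two cores is not broken down here. In this assay compound 3 gives 0.0063 ug/mL, and this number and that of compound 1 lie within the scatter of each other.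

Compound 4 `COc1ccccc1N1CCN(CC(O)COc2ccc3c(-c4ccccc4)cc(=O)oc3c2)CC1` has not yet been measured. It differs from compound 3 by methoxy in place of hydrogen on an aromatic carbon, the same change that turns compound 1 into compound 2, at the same kind of place. The expectation for compound 4 rests on that earlier pair, because a 1.0-fold lower number from compound 1 to compound 2 (0.01 log units; within the scatter) was a step within the scatter. Compound 4 is therefore expected to give 0.0063 ug/mL in this assay. The step from compound 3 is estimated as no change at the digits printed from compound 3 to compound 4 (within the scatter). The estimate for compound 4 spans from 0.003 ug/mL to 0.013 ug/mL.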

Compound 4, half-maximal effective concentration: 0.0062 ug/mL
Beside the measured number, compound 4's estimate is 1.0-fold (0.01 log units) above it; the range from low to high includes it.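

In this assay, placing methoxy on the aromatic ring, ortho to a large group, gave a 1.0-fold lower number from compound 3 to compound 4 (0.01 log units; within the scatter). Set beside the earlier pair, the same change looks alike on the two cores: the same change on two cores in this assay, a 1.0-fold lower number (0.01 log units; within the scatter) from compound 1 to compound 2 and a 1.0-fold lower number (0.01 log units; within the scatter) from compound 3 to compound 4, 1.0-fold (0.00 log units) apart, within the scatter of two such steps. Within the data shown here, this shows that on both cores, the swap from phenyl to 2-methoxyphenyl left the read-out where it was, but it does not show that a real gain or loss would carry from one core to the other, since neither step rises above the scatter and only two cores are compared.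

The compounds shown leave open what a different group in the same place would do, such as a chlorine atom, an amine, a carboxylic acid or a longer chain like butoxy. They also leave open whether any such group would move the number on one core and not on the other, which would be a stricter test of carrying a change across cores.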